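Methoxyphenyl position change from compound 2 to compound 4

The source may hold more compounds than are shown below. What is called first, only, known or untested is meant among the compounds shown, and "the series" means these compounds.

Measured compounds:
- compound 1 `Cc1ccc(Nc2nc(C)c(C(=O)/C=C/c3ccc(Cl)cc3)s2)cc1`: in a functional assay on PC-3 cells (Homo sapiens) for cytotoxicity, read by MTT assay (on this read-out lower numbers stand for stronger inhibition and higher numbers for weaker inhibition), compound 1 gives > 25000 nM, which is a limit of the assay.
- compound 2 `COc1cccc(/C=C/C(=O)c2sc(Nc3ccc(Cl)c(Cl)c3)nc2C)c1`: in this assay compound 2 gives 10100 nM.
- compound 3 `Cc1cccc(Nc2nc(C)c(C(=O)/C=C/c3ccc(Cl)cc3)s2)c1`: in this assay compound 3 gives > 25000 nM, which is a limit of the assay.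

For the measured compounds named here, compound 2 holds the only number in the set; the two other values are limits, as noted in the limit of > 25000 nM in this assay, at which 2 of the 3 values shown sit. The step that the two limits leave unreadable from compound 1 to compound 3 is therefore not readable in size and, besides, changes the aryl on the nitrogen rather than the aryl on the chain.

Compound 4 `COc1ccc(/C=C/C(=O)c2sc(Nc3ccc(Cl)c(Cl)c3)nc2C)cc1` is not yet measured in this assay. It differs from compound 2 by 4-methoxyphenyl in place of 3-methoxyphenyl on a double-bonded chain carbon bound to a double-bonded chain carbon. Going by the values given here, no measured step in the set moves the methoxy position on that aryl, so there is no direct precedent for the size or direction of this change. With nothing to point either way, no step beyond the usual scatter is expected: the estimated step of a 1.0-fold lower number from compound 2 to compound 4 (0.00 log units; within the scatter) is flat. Compound 4 is expected to give about 10000 nM, within a range from 4000 nM to 25000 nM, with a fair chance that only a limit is reported.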

Compound 4, half-maximal inhibitory concentration: > 25000 nM
Compound 4: no number, only a limit; the forecaster's own chance of this, stated with the estimate: 30%; middle value at least 2.5-fold (0.39 log units) away from the limit.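

In this assay, for the compounds shown here, 4-methoxyphenyl in place of 3-methoxyphenyl on a double-bonded chain carbon bound to a double-bonded chain carbon gives an at least 2.4-fold higher number from compound 2 to compound 4 (0.39 log units; beyond the scatter), the first step in the set whose size can be read at all, since the earlier step from compound 1 to compound 3 cannot be read. Compound 4 gives > 25000 nM, which is a limit of the assay. Going by these compounds alone, the two groups hold the same atoms, joined differently, so for this pair the read-out responds to where the methoxy stands on the aryl of the chain alone, which no earlier pair could show.

Within the data shown here, how far compound 4 lies past its limit stays unknown, and only a minimum can be given for the step, with compound 2 alone carrying a number: the limit of > 25000 nM in this assay, at which 3 of the 4 values shown sit. Also open are what an amine or a carboxylic acid in place of the methoxy on that aryl would give, and whether the gap between 3-methoxyphenyl and 4-methoxyphenyl holds with any aryl on the nitrogen other than the one shared by compound 2 and compound 4.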